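The source may hold more compounds than are shown below. What is called first, only, known or untested is meant among the compounds shown, and "the series" means these compounds.

Compound 1 `S=C(N/N=C/c1ccc2ccccc2n1)Nc1ccc(Br)cc1` gives 56800 nM in a functional assay on HeLa cells (Homo sapiens) for antiproliferative activity, read by sulforhodamine B assay, with a stated time of 72 h (on this read-out higher numbers stand for weaker inhibition and lower numbers for stronger inhibition), the highest of the two numbers recorded here. Compound 2 `NC(=S)N/N=C/c1cc2cccnc2s1` gives 6290 nM in this assay, a lower number that lies beyond the usual scatter. Compound 3 `NC(=S)N/N=C/c1cnc2ccccc2n1` reaches only a limit in this assay, > 100000 nM, so no number is known for it. Compound 4 `COc1ccc(NC(=S)N/N=C/c2ccc3ccccc3n2)cc1` differs from compound 1 in one place: methoxy in place of bromo on an aromatic carbon. Within the data shown here, no measured pair shows what this change does, and the other two compounds differ from compound 1 in more than one place. The change is therefore expected to give a step within the scatter in this assay, estimated as a 1.1-fold higher number from compound 1 to compound 4 (0.06 log units; within the scatter). Compound 4 is expected to give about 65000 nM in this assay, within a range from 25000 nM to 150000 nM.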

Compound 4, half-maximal inhibitory concentration: 72600 nM
For compound 4 the middle estimate is 1.1-fold (0.05 log units) below the measured one, within the range that was stated.
By their numbers in this assay, from the lowest: compound 2; then compounds 1 and 4 (each within the scatter of the next). At a limit, above all of these: compound 3.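

Going from 4-bromophenyl to 4-methoxyphenyl gives the first pair that differs at this position alone, and in this assay the change yields a 1.3-fold higher number from compound 1 to compound 4 (0.11 log units; within the scatter). Bromo and methoxy therefore cannot be told apart at this position by this read-out. Any upward shift has limited room to show, because the read-out stops at a limit, which compound 3 reaches: the limit of > 100000 nM in this assay, at which 1 of the 4 values shown sits.

From the compounds shown here alone, whether an amine, a carboxylic acid or a longer chain at this position would move the number stays open. So does whether methoxy in place of bromo would behave the same way on a different core.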